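Aryl variation on the shared core: antiproliferative working notes

The source may report more compounds than this note shows. Statements on the series, on what has been measured and on what is new or still open speak of the compounds shown alone.

Measured so far:
compound 1 `CC(C)(C)c1ccc(-c2cc(N3CCC(CCNS(N)(=O)=O)CC3)ncn2)cc1` — 18400 nM
compound 2 `COc1ccc(-c2cc(N3CCC(CCNS(N)(=O)=O)CC3)ncn2)cc1` — 69800 nM
compound 3 `COC(=O)c1ccc(-c2cc(N3CCC(CCNS(N)(=O)=O)CC3)ncn2)cc1` — 19600 nM

All three were read in a functional assay on M21 cells (Homo sapiens) for antiproliferative activity, read by sulforhodamine B assay, with a stated time of 48 h; a lower number here means a stronger inhibitor of growth, a higher number a weaker inhibitor of growth. Compound 2 stands highest of the three numbers. Its nearest neighbour is compound 3, reached by a 3.6-fold lower number from compound 2 to compound 3 (0.55 log units; beyond the scatter), and the other step into it, a 3.8-fold higher number from compound 1 to compound 2 (0.58 log units; beyond the scatter), is of about the same size in the opposite sense. Compound 1 and compound 3 lie within the scatter of each other, as a 1.1-fold higher number from compound 1 to compound 3 (0.03 log units; within the scatter) shows.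

Compound 4 `NS(=O)(=O)NCCC1CCN(c2cc(-c3ccccc3F)ncn2)CC1` differs from compound 2 in one place: 2-fluorophenyl in place of 4-methoxyphenyl on an aromatic carbon. For the measured compounds named here, no measured step exchanges a group on the pendant aryl ring for a group at a different position of that ring, so none of the three steps bears directly on this change. What they do show is that both measured departures from the 4-methoxyphenyl of compound 2 gave lower numbers, each by a modest margin, while compound 1 and compound 3 did not separate from one another. On that basis a modest lowering from compound 2 is expected, of roughly the size already seen within the set, though the new position of the substituent leaves the direction less secure than for a like-for-like swap.

Compound 4 is therefore expected near 30000 nM, with a range of 10000 nM to 90000 nM, the expected step being a 2.3-fold lower number from compound 2 to compound 4 (0.37 log units; beyond the scatter).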

Compound 4, concentration for 50% growth inhibition: 81800 nM
The estimate for compound 4 lay 2.7-fold (0.44 log units) below the measured number, and the stated range covers the measured number.
By their numbers in this assay, from the lowest: compounds 1 and 3 (each within the scatter of the next); then compounds 2 and 4 (each within the scatter of the next).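

In this assay, the exchange of 4-methoxyphenyl for 2-fluorophenyl gives a 1.2-fold higher number from compound 2 to compound 4 (0.07 log units; within the scatter), so these two aryl groups do not separate at this position of the shared core. The earlier steps shown here away from 4-methoxyphenyl, to the aryl groups of compound 1 and compound 3, both gave lower numbers beyond the scatter, and this result shows that a lower number does not follow from every replacement of 4-methoxyphenyl, so any trend among the aryl groups depends on which group enters. The entering group also carries no hydrogen-bond acceptor where the leaving group carries one, and that difference comes with no separation of the numbers, while no available measurement explains the result.

The compounds shown leave open how much of this step belongs to the change of substituent and how much to its new place on the aryl ring, as the two change together here. They also leave open where unsubstituted phenyl, or an aryl ring bearing an amine or a carboxylic acid, would stand against compound 2 and compound 4.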